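This account rests on a few compounds, and the source may have more. Where it says the series, first, only, none or still open, it means among the compounds named here.

Compound 3 `COC(=O)/C=C/c1cccc(N(Cc2ccccc2)C(=O)C2CCCCC2)c1` carries hydrogen on the aromatic carbon under study. In an assay on isolated protein with Bile acid receptor (Homo sapiens) as the target (on this read-out higher numbers stand for an effect only at larger amounts of compound and lower numbers for an effect already at smaller amounts), compound 3 reaches only the limit of the assay, > 1000 nM, which is a limit and not a measured number (the limit of > 1000 nM in this assay, at which 1 of the 3 values shown sits). Compound 1 `COC(=O)/C=C/c1cccc(N(Cc2ccc(/C=C/c3scnc3C)cc2)C(=O)C2CCCCC2)c1` gives 227 nM in this assay, and compound 2 `CCOc1cccc(-c2ccc(CN(C(=O)C3CCCCC3)c3cccc(/C=C/C(=O)OC)c3)cc2)c1` gives 147 nM, so compound 3 stands apart from both of them. The move to compound 4 `COC(=O)/C=C/c1cccc(N(Cc2ccc(/C=C/c3cccc(Cl)c3)cc2)C(=O)C2CCCCC2)c1` is 2-(3-chlorophenyl)ethenyl in place of hydrogen on an aromatic carbon. Among the compounds with values here, two measured steps bear on this change: removing the 2-(4-methyl-1,3-thiazol-5-yl)ethenyl gave an at least 4.4-fold higher number from compound 1 to compound 3 (0.64 log units; beyond the scatter), and removing the 3-ethoxyphenyl gave an at least 6.8-fold higher number from compound 2 to compound 3 (0.83 log units; beyond the scatter). In both cases a larger group on this aromatic carbon, in place of hydrogen, went with a markedly lower number, and the 2-(3-chlorophenyl)ethenyl entering compound 4 resembles the group of compound 1 in carrying one six-membered aromatic ring and a double bond outside aromatic rings. A clear fall in the number is therefore expected for compound 4, an at least 5.0-fold lower number from compound 3 to compound 4 (0.69 log units; beyond the scatter), in this assay. Compound 4 is estimated at 200 nM, with a likely range from 70 nM to 600 nM.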

Compound 4, half-maximal effective concentration: 165 nM
The estimate for compound 4 lay 1.2-fold (0.08 log units) above the measured number, within the range that was stated.
By their numbers in this assay, from the lowest: compounds 2, 4 and 1 (each within the scatter of the next). At a limit, above all of these: compound 3.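

In this assay, an at least 6.0-fold lower number from compound 3 to compound 4 (0.78 log units; beyond the scatter) came with 2-(3-chlorophenyl)ethenyl in place of hydrogen, so a third large group on this aromatic carbon, para to a large group, goes the same way as the two earlier ones. On these data alone, compound 3 stands at a limit and not at a measured number, so the size of this step stays open on one side: the limit of > 1000 nM in this assay, at which 1 of the 4 values shown sits. The three large groups themselves are not told apart, with a 1.1-fold higher number from compound 2 to compound 4 (0.05 log units; within the scatter) for 2-(3-chlorophenyl)ethenyl in place of 3-ethoxyphenyl, and a 1.4-fold lower number from compound 1 to compound 4 (0.14 log units; within the scatter) for 3-chlorophenyl in place of 4-methyl-1,3-thiazol-5-yl.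

As far as these compounds go, what a plain alkyl chain such as butyl would give on this aromatic carbon remains open. So does whether an amine or a carboxylic acid on the outer ring would move the number beyond the scatter.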